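Changing the Aryl Group on the Amide-Type Ring Nitrogen

The source may report more compounds than this note shows. Statements on the series, on what has been measured and on what is new or still open speak of the compounds shown alone.

Three compounds sharing one core have been run in an ADME assay on microsomes from liver (Canis lupus familiaris) for metabolic stability, read by LC-MS, using NADPH, with a stated time of 10 min, tested at 0.1 uM; on this read-out higher numbers stand for fast clearance and lower numbers for slow clearance. Compound 1 `COc1ccccc1N1C(=O)C(C)SC1c1cccc(C(=O)NCCCCc2ccccc2)c1` gives 1170 mL.min-1.g-1. Compound 2 `C#Cc1cccc(N2C(=O)CSC2c2cccc(C(=O)NCCCCc3ccccc3)c2)c1` gives 973 mL.min-1.g-1, the second highest of the three numbers and within the scatter of compound 1. Compound 3 `Cc1ccnc(N2C(=O)CSC2c2cccc(C(=O)NCCCCn3cccn3)c2)c1`, which differs from the others in several places, gives 41.8 mL.min-1.g-1, well beyond the scatter below compound 2.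

Compound 4 `COc1ccc(F)cc1N1C(=O)CSC1c1cccc(C(=O)NCCCCc2ccccc2)c1` has not yet been measured in this assay. It differs from compound 2 in one place: 5-fluoro-2-methoxyphenyl in place of 3-ethynylphenyl on an amide-type nitrogen in a ring. Among the measured compounds shown here, no single-point step between measured compounds is available to guide the change. The closest reference is compound 1, which carries a 2-methoxyphenyl at the same place and gives 1170 mL.min-1.g-1, a number within the scatter of compound 2. On that basis compound 4 is expected to stay in the same high region, with a step of a 1.0-fold higher number from compound 2 to compound 4 (0.01 log units; within the scatter), which is no step beyond the scatter. The estimate for compound 4 in this assay is 1000 mL.min-1.g-1, with a range from 400 mL.min-1.g-1 to 2500 mL.min-1.g-1.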

Compound 4, intrinsic clearance in microsomes: 1650 mL.min-1.g-1
Compound 4: middle estimate off by 1.7-fold (0.22 log units), on the low side, within the range that was stated.
By their numbers in this assay, from the lowest: compound 3; then compounds 2, 1 and 4 (each within the scatter of the next).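

In this assay, among the compounds shown here, the first step at this position with only one place changed is a 1.7-fold higher number from compound 2 to compound 4 (0.23 log units; within the scatter), and it stays within the scatter. On the amide-type nitrogen in a ring, 5-fluoro-2-methoxyphenyl, with its oxygen and fluorine, and 3-ethynylphenyl, with its triple bond, therefore cannot be told apart on this read-out, although the two groups differ in their atoms. Nothing measured here gives a reason for this result.

From the compounds shown here alone, whether any group at this nitrogen can move the number beyond the scatter remains open, for instance a phenyl carrying a carboxylic acid or an aliphatic amine. Compound 3 gives 41.8 mL.min-1.g-1, but it differs from the others in several places, so the group on that nitrogen and the chain end cannot be separated.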